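The compounds below may be only part of what the source reports. "The series", "measured", "known", "first", "only" and "open" are said of these compounds alone.

Among the measured compounds shown here, compound 3, `Cc1ccc(-n2cc(CNC(=O)c3cccc4c3cnn4C(C)C)nn2)c(C)c1`, is one of three compounds measured so far in a functional assay on MGC-803 cells (Homo sapiens) for inhibition, read by MTT assay, with a stated time of 72 h; a higher number here means a weaker inhibitor, a lower number a stronger inhibitor. In this assay compound 3 gives > 40000 nM, which is a limit of the assay rather than a measured number. Compound 1, `CC(C)n1ncc2c(C(=O)Nc3cccnc3)cccc21`, gives > 40000 nM, likewise a limit. Compound 2, `CC(C)n1ncc2c(C(=O)NCc3ccccc3)cccc21`, gives > 40000 nM, once more a limit. The only single-point step among these, a step that the two limits leave unreadable from compound 1 to compound 2, therefore cannot be read: two limits give no size and no direction. Where compound 3 stands is thus simple to say: it sits together with the other two at the edge of what this assay can report, as the one piece of evidence states, (the limit of > 40000 nM in this assay, at which 3 of the 3 values shown sit).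

Compound 4, `Cc1ccc(-n2cc(CNC(=O)c3cccc4c3cnn4C(C)C)nn2)cc1`, has not yet been measured. It differs from compound 3 by hydrogen in place of methyl on an aromatic carbon. For the measured compounds named here, no measured step bears on this change, since every value so far is a limit; nothing shows whether removing one methyl from the aromatic ring shifts inhibition at all. With compound 3 showing no inhibition inside the measurable range, compound 4 is expected to stay there as well, and the expected step, a number no higher from compound 3 to compound 4 (the limit leaves the size open), is no movement beyond the scatter. The estimate for compound 4 in this assay is 40000 nM, with a range from 15000 nM to 100000 nM.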

Compound 4, half-maximal inhibitory concentration: > 40000 nM
Compound 4: no number, only a limit; the forecaster's own chance of this, stated with the estimate: 80%; the middle value sits exactly at the limit.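

Compound 3 and compound 4 both give only a limit in this assay, so the step between them cannot be read, either in size or in direction: the limit of > 40000 nM in this assay, at which 4 of the 4 values shown sit. The compounds shown leave open whether any change to the shared core or its side groups can bring a value within the measurable range of this assay at all.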